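The source may report more compounds than this note shows. Statements on the series, on what has been measured and on what is new or still open speak of the compounds shown alone.

Among the measured compounds shown here, in a functional assay on A549 cells (Homo sapiens) for cytotoxicity, read by MTT assay, with a stated time of 4 days (a lower number here means a stronger inhibitor, a higher number a weaker inhibitor), compound 2 (`COc1cc(C[C@H]2C(=O)OC[C@@H]2Cc2ccc(OC)c(OC)c2)ccc1Nc1ccc([N+](=O)[O-])cc1`) gives 22100 nM, the only actual number so far. Compound 1 (`CCC(=O)Nc1ccc(C[C@H]2C(=O)OC[C@@H]2Cc2ccc(OC)c(OC)c2)cc1OC`) reads > 50000 nM, which is a limit of the assay and not a number. For the measured compounds named here, one measured step bears on what follows: an at least 2.2-fold lower number from compound 1 to compound 2 (0.35 log units; beyond the scatter). It came from placing 4-nitrophenyl instead of propanoyl on the nitrogen, and it is modest, beyond the scatter, with one end resting on a limit. Compound 3 (`COc1cccc(C[C@H]2C(=O)OC[C@@H]2Cc2ccc(OC)c(OC)c2)c1`) differs from compound 2 by hydrogen in place of (4-nitrophenyl)amino on an aromatic carbon, with hydrogen in place of (4-nitrophenyl)amino on an aromatic carbon. With compound 1 at > 50000 nM, losing the 4-nitrophenyl group gave a higher reading, so a similarly modest rise is expected in this assay here, and a limit reading would be no surprise. The expected change is a 1.9-fold higher number from compound 2 to compound 3 (0.28 log units; within the scatter). For compound 3 the estimated value is 42000 nM, within a range of 16000 nM to 100000 nM.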

Compound 3, half-maximal inhibitory concentration: > 50000 nM
Compound 3 gave a limit, no number (the forecaster's own chance of this, stated with the estimate: 45%); at least 1.1-fold (0.07 log units) between middle value and limit.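

In this assay, replacing the (4-nitrophenyl)amino group with hydrogen on the aromatic carbon gives an at least 2.2-fold higher number from compound 2 to compound 3 (0.35 log units; beyond the scatter), so removing the group entirely has a measured effect beyond the scatter, although one end of the step rests on a limit. The reading for compound 3, > 50000 nM, is a limit of the assay and not a number. Compound 1 and compound 3 both rest on a limit, so the step between them cannot be read, and among the three groups at this position only the (4-nitrophenyl)amino group gives an actual number: the limit of > 50000 nM in this assay, at which 2 of the 3 values shown sit.

The compounds shown leave open whether the nitro group is needed or whether a plain phenylamino group would also give a number. Among the compounds shown here, with only one actual value, they also leave open how far compound 1 and compound 3 lie from compound 2.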